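The source may hold more compounds than are shown below. What is called first, only, known or untested is meant among the compounds shown, and "the series" means these compounds.

Measured compounds:
Compound 1 `CCN(CC)c1cc2[nH]c(C3CCCCC3)nc2cc1NC(=O)NCc1ccccc1` — in an ADME assay on Vero cells (Chlorocebus sabaeus) for cytotoxicity, read by resazurin assay, with a stated time of 3 days (a higher number here means a weaker inhibitor, a lower number a stronger inhibitor), compound 1 gives > 100 ug/mL, a limit of the assay.
Compound 2 `O=C(NCc1ccccc1)Nc1cc2nc(C3CCCCC3)[nH]c2cc1N1CCCC1` — compound 2 gives > 100 ug/mL, again a limit.
Compound 3 `CCCOCC(=O)Nc1cc2nc(C3CCCCC3)[nH]c2cc1N(CC)CC` — compound 3 gives > 100 ug/mL, also a limit.

Compound 2 therefore stands at the limit in this assay, and it does not stand alone there: the limit of > 100 ug/mL in this assay, at which 3 of the 3 values shown sit. The two steps that connect the measured compounds, a step that the two limits leave unreadable from compound 1 to compound 2 and a step that the two limits leave unreadable from compound 1 to compound 3, cannot be read in size because the limit of > 100 ug/mL in this assay, at which 3 of the 3 values shown sit, covers both of their ends.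

Compound 4 `CCCCCC(=O)Nc1cc2nc(C3CCCCC3)[nH]c2cc1N1CCCC1` differs from compound 2 in one place: pentyl in place of benzylamino on a carbonyl carbon. Cut one bond further out, the change reads benzylcarbamoyl to pentylcarbonyl. Among the compounds with values here, the only measured step that touches the same carbonyl carbon is a step that the two limits leave unreadable from compound 1 to compound 3, and it is unreadable, so no measured step gives a direction or a size for the change from compound 2 to compound 4.

With every value on hand sitting at the limit, compound 4 is expected to stay close to it as well, which means a step that the limit leaves unreadable from compound 2 to compound 4 is expected. Compound 4 is thus estimated at 150 ug/mL, with a range from 60 ug/mL to 400 ug/mL, and most likely the assay will again report only a limit.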

Compound 4, half-maximal inhibitory concentration: > 100 ug/mL
Compound 4 ended at the assay's limit; the forecaster's own chance of this, stated with the estimate: 80%; the middle value is on the limit's open side.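

Compound 2 and compound 4 both sit at a limit of the assay, so no new step can be read between them, because the values share one bound: the limit of > 100 ug/mL in this assay, at which 4 of the 4 values shown sit. The compounds shown leave open how far any of them lies past that limit in this assay, and whether any change to the shared core would bring a value within range.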